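Removing One Fluorine From Three Inactive Hydrazones

The compounds below may be only part of what the source reports. "The series", "measured", "known", "first", "only" and "open" are said of these compounds alone.

Three measured compounds share one core and differ only in the ring on the carbon with a double bond to nitrogen. Compound 1 `Cc1nc(N(C)C(=O)NC(=O)c2c(F)cccc2F)sc1C(=O)N/N=C/c1ccccc1Cl` carries a 2-chlorophenyl there, compound 2 `Cc1nc(N(C)C(=O)NC(=O)c2c(F)cccc2F)sc1C(=O)N/N=C/c1ccc(F)cc1` a 4-fluorophenyl, and compound 3 `Cc1nc(N(C)C(=O)NC(=O)c2c(F)cccc2F)sc1C(=O)N/N=C/c1ccccc1F` a 2-fluorophenyl. In a functional assay on HepG2 cells (Homo sapiens) for inhibition, read by MTT assay, with a stated time of 72 h (a higher number here means a weaker inhibitor, a lower number a stronger inhibitor), compound 1 gives > 100 ug/mL, which is a limit of the assay and not a number. Compound 2 likewise gives only a limit, > 100 ug/mL. Compound 3 also stands at a limit, > 100 ug/mL, so its place among the others cannot be ranked. Because of the limit of > 100 ug/mL in this assay, at which 3 of the 3 values shown sit, none of the steps between them can be sized: a step that the two limits leave unreadable from compound 1 to compound 2, a step that the two limits leave unreadable from compound 1 to compound 3 and a step that the two limits leave unreadable from compound 2 to compound 3 all stay unreadable. Compound 4 `Cc1nc(N(C)C(=O)NC(=O)c2c(F)cccc2F)sc1C(=O)N/N=C/c1ccccc1` is the next variation: hydrogen in place of fluoro on an aromatic carbon. Among the measured compounds shown here, no measured step bears on this change with a readable size, and every neighbour sits at the same limit. Compound 4 is therefore expected to give about 150 ug/mL, within a range from 60 ug/mL to 400 ug/mL, most likely reported again only as a limit. The step this estimate means, a step that the limit leaves unreadable from compound 3 to compound 4, is expected to stay within the scatter.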

Compound 4, half-maximal inhibitory concentration: 54.3 ug/mL
Compound 4: the middle estimate sits 2.8-fold (0.44 log units) above what was measured, and the stated range ends above it.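

In this assay, among the compounds shown here, compound 4, with a plain phenyl on the carbon with a double bond to nitrogen, gives 54.3 ug/mL, the only actual number among the four compounds. Replacing the halogen on this ring with hydrogen gives an at least 1.8-fold lower number from compound 3 to compound 4 (0.26 log units; that floor lies within the scatter), an at least 1.8-fold lower number from compound 2 to compound 4 (0.26 log units; that floor lies within the scatter) and an at least 1.8-fold lower number from compound 1 to compound 4 (0.26 log units; that floor lies within the scatter). Each of these sizes is only a floor, because the other three compounds stop at a limit: the limit of > 100 ug/mL in this assay, at which 3 of the 4 values shown sit.

Going by these compounds, it remains open whether a readable number requires this ring to carry no substituent, or whether a methyl, a methoxy or an amine in the same place would also give one. On these data alone, the true size of each step also remains open, as does any ranking among the three halogen-bearing compounds.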